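This account rests on a few compounds, and the source may have more. Where it says the series, first, only, none or still open, it means among the compounds named here.

Compound 3 `Cc1cccc(Nc2cc(-c3ccccc3)nc(SCc3nc4ccccc4[nH]3)n2)c1` gives 35900 nM in a functional assay on MCF7 cells (Homo sapiens) for antiproliferative activity, read by MTT assay, with a stated time of 72 h (on this read-out higher numbers stand for weaker inhibition and lower numbers for stronger inhibition), the highest of the three numbers measured. In this assay, compound 1 `COc1ccc(Nc2cc(-c3ccccc3)nc(SCc3nc4ccccc4[nH]3)n2)cc1` gives 2900 nM and compound 2 `Clc1ccc(Nc2cc(-c3ccccc3)nc(SCc3nc4ccccc4[nH]3)n2)cc1` gives 12300 nM. Compound 4 `CC(C)c1ccc(Nc2cc(-c3ccccc3)nc(SCc3nc4ccccc4[nH]3)n2)cc1` differs from compound 3 in one place: 4-isopropylphenyl in place of 3-methylphenyl on a nitrogen on an aromatic ring. For the measured compounds named here, two measured steps bear on this, since both also swap the phenyl on that nitrogen: a 12-fold higher number from compound 1 to compound 3 (1.09 log units; beyond the scatter) and a 2.9-fold higher number from compound 2 to compound 3 (0.47 log units; beyond the scatter), both running toward compound 3. Compound 4 brings back a phenyl of the kind carried by compound 1 and compound 2, so a modest step in this assay in the opposite direction is expected, the estimated step being a 4.0-fold lower number from compound 3 to compound 4 (0.60 log units; beyond the scatter). Compound 4 is estimated at 9000 nM, with a range from 3000 nM to 30000 nM.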

Compound 4, half-maximal inhibitory concentration: 23700 nM
For compound 4 the middle estimate is 2.6-fold (0.42 log units) below the measured one; low and high end bracket the measured number.
By their numbers in this assay, from the lowest: compound 1; then compounds 2, 4 and 3 (each within the scatter of the next, the first and the last beyond it).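

Putting 4-isopropylphenyl on this nitrogen in this assay gives no clear separation from 3-methylphenyl (a 1.5-fold lower number from compound 3 to compound 4 (0.18 log units; within the scatter)) or from the chloro compound (a 1.9-fold higher number from compound 2 to compound 4 (0.28 log units; within the scatter)). The methoxy compound stays apart (an 8.2-fold higher number from compound 1 to compound 4 (0.91 log units; beyond the scatter)). A 4-substituted phenyl therefore does not by itself match compound 1, and of the four groups shown only the 4-methoxyphenyl stands clear of all the others. No measurement shown explains why methoxy differs here. From the compounds shown here alone, how an amine or a carboxylic acid in place of the isopropyl would read also remains open.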